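The source may report more compounds than this note shows. Statements on the series, on what has been measured and on what is new or still open speak of the compounds shown alone.

Measured so far:
compound 1, `COc1ccc(OC)c(/C=C/c2nnc(Nc3ccc(Cl)cc3)o2)c1`, 7400 nM
compound 2, `COc1ccc(OC)c(/C=C/C(=O)N/N=C/c2ccc(Cl)cc2)c1`, 691 nM

Of the compounds shown here, two have been tested in a functional assay on TK-10 cells (Homo sapiens) for antiproliferative activity, read by sulforhodamine B assay, with a stated time of 48 h; a lower number here means a stronger inhibitor of growth, a higher number a weaker inhibitor of growth. Compound 1 gives 7400 nM, and compound 2 gives 691 nM. Compound 2 therefore holds the lowest number of the two; its nearest neighbour is compound 1, whose number lies higher by a margin beyond the scatter of repeated measurements. Compound 3, `COc1ccc(OC)c(/C=C/C(=O)N/N=C/c2ccccc2)c1`, has not yet been measured. It differs from compound 2 in one place: hydrogen in place of chloro on an aromatic carbon. Among the compounds with values here, no pair of measured compounds differs in exactly one place, so there is no measured step of this kind to lean on. The chlorine is a small part of compound 2, and the expectation is that losing it shifts the number only a little, towards a weaker inhibitor. The step of a 2.2-fold higher number from compound 2 to compound 3 (0.34 log units; beyond the scatter) is expected to be modest, at the edge of the scatter. For compound 3 the estimate is 1500 nM, with a range from 500 nM to 5000 nM.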

Compound 3, concentration for 50% growth inhibition: 16600 nM
For compound 3 the middle estimate is 11-fold (1.04 log units) below the measured one, outside the stated range (above it).
By their numbers in this assay, from the lowest: compound 2; then compound 1; then compound 3.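

In this assay, the change from 4-chlorophenyl to phenyl gives a 24-fold higher number from compound 2 to compound 3 (1.38 log units; beyond the scatter), a large step for the loss of a single heavy atom. Within the data shown here, this is the first measured step between two compounds that differ in only one place, and it shows that this position, para to a large group on the six-membered aromatic ring, is sensitive to what stands there: with chloro the compound is a much stronger inhibitor of growth than with hydrogen. Nothing at hand explains why the step is so large.

The compounds shown compare only chloro and hydrogen at this place, so it stays open how fluoro, bromo, methoxy or an amine would compare. On these data alone, it also stays open whether losing the chloro from compound 1 would give a similar step.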